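Cyclohexyl for Cyclopropyl on Two Related Cores

This account rests on a few compounds, and the source may have more. Where it says the series, first, only, none or still open, it means among the compounds named here.

Three compounds have been measured in a functional assay on A549 cells (Homo sapiens) for cytotoxicity, read by sulforhodamine B assay, with a stated time of 72 h; on this read-out lower numbers stand for stronger inhibition and higher numbers for weaker inhibition:

Compound 1 `Nc1sc(-c2ccc(Br)cc2)c(-c2ccc(Cl)cc2)c1C(=O)NC1CC1`: in this assay compound 1 reaches only a limit of the assay, > 50000 nM.
Compound 2 `Nc1sc(-c2ccc(Br)cc2)c(-c2ccc(Cl)cc2)c1C(=O)NC1CCCCC1`: compound 2 gives 9590 nM.
Compound 3 `Clc1ccc(-c2sc3ncnc(NC4CC4)c3c2-c2ccc(Cl)cc2)cc1`: compound 3 gives 42800 nM.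

Compound 1 and compound 2 share one core and differ in a single place, (cyclohexyl in place of cyclopropyl on an amide-type nitrogen). That change gave an at least 5.2-fold lower number from compound 1 to compound 2 (0.71 log units; beyond the scatter), a step that goes beyond the usual scatter, though its true size is open because compound 1 sits at the limit of > 50000 nM in this assay, at which 1 of the 3 values shown sits.

Compound 3 is built on a different core; how the two cores differ is not broken down here. Its number in this assay stands above that of compound 2, and the gap between the two is beyond the scatter.

Compound 4 `Clc1ccc(-c2sc3ncnc(NC4CCCCC4)c3c2-c2ccc(Cl)cc2)cc1` has not yet been measured. It differs from compound 3 by cyclohexyl in place of cyclopropyl on a nitrogen on an aromatic ring. Within the data shown here, this is the same kind of change as the one from compound 1 to compound 2, but the place is not the same: there the cyclohexyl sits on an amide-type nitrogen whose other neighbour is a carbonyl carbon, here on a nitrogen on an aromatic ring whose other neighbour is an aromatic carbon. Because the earlier change gave an at least 5.2-fold lower number from compound 1 to compound 2 (0.71 log units; beyond the scatter), a step of similar direction is expected for compound 4, namely a 4.8-fold lower number from compound 3 to compound 4 (0.68 log units; beyond the scatter). Compound 4 is therefore estimated at 9000 nM, with a likely range from 3000 nM to 30000 nM.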

Compound 4, half-maximal inhibitory concentration: > 50000 nM
Compound 4 gave a limit, no number; the forecaster's own chance of this, stated with the estimate: 5%; middle value at least 5.5-fold (0.74 log units) away from the limit.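

In this assay, putting cyclohexyl in place of cyclopropyl on a nitrogen on an aromatic ring gave an at least 1.1-fold higher number from compound 3 to compound 4 (0.06 log units; that floor lies within the scatter), so the clear drop seen on the core of compound 1 did not reappear on the core of compound 3. The change therefore did not carry over from one core to the other in this series, and the two steps can be told apart: the same change on two cores in this assay, an at least 5.2-fold lower number (0.71 log units; beyond the scatter) from compound 1 to compound 2 and an at least 1.1-fold higher number (0.06 log units; that floor lies within the scatter) from compound 3 to compound 4, at least 6.0-fold (0.78 log units) apart, beyond the scatter of two such steps. Among these compounds, this does not show how large the step on the second core really is, nor does it give a rule for any further core, since only two cores are compared and compound 1 and compound 4 each stand at a limit rather than at a number: the limit of > 50000 nM in this assay, at which 2 of the 4 values shown sit.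

The compounds shown leave open why the same swap behaves differently on the two cores, as the nitrogen carrying the ring is an amide-type nitrogen in one pair and a nitrogen on an aromatic ring in the other. They also leave open whether rings of intermediate size such as cyclobutyl or cyclopentyl, or an open chain such as n-butyl, would follow the first core's trend or the second's on either nitrogen.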